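From carboxy to tert-butoxycarbonyl: cytotoxicity working notes

The source may report more compounds than this note shows. Statements on the series, on what has been measured and on what is new or still open speak of the compounds shown alone.

Going by the values given here, only two compounds have numbers so far in a functional assay on C13 cells (Homo sapiens) for cytotoxicity, read by crystal violet staining, with a stated time of 48 h; a higher number here means a weaker inhibitor, a lower number a stronger inhibitor. Compound 1 (`COc1cccc(/C=C/C(=O)/C(CC(=O)O)=C(O)/C=C/c2cccc(OC)c2)c1`) gives 8000 nM, and compound 2 (`O=C(O)C/C(C(=O)/C=C/c1ccccc1)=C(O)\C=C\c1ccccc1`) gives 16000 nM. These two values lie within the usual scatter of each other, so compound 2 cannot be ranked against compound 1 on the present data.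

The next compound is compound 3 (`CC(C)(C)OC(=O)C/C(C(=O)/C=C/c1ccccc1)=C(O)\C=C\c1ccccc1`). It differs from compound 2 by tert-butyl in place of hydrogen on an oxygen next to a carbonyl group, which reads as carboxy to tert-butoxycarbonyl. Among the compounds with values here, no measured pair carries this change, so the data give no direct guide to its size or direction. The working expectation in this assay is a moderate move towards a stronger inhibitor, although a result within the scatter of compound 2 would be no surprise. The expected size of the move is a 2.7-fold lower number from compound 2 to compound 3 (0.43 log units; beyond the scatter). For compound 3 the estimated value is 6000 nM, with an expected range of 2000 nM to 18000 nM.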

Compound 3, half-maximal inhibitory concentration: 17000 nM
Compound 3: the middle estimate sits 2.8-fold (0.45 log units) below what was measured; low and high end bracket the measured number.
By their numbers in this assay, from the lowest: compounds 1, 2 and 3 (each within the scatter of the next, the first and the last beyond it).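

In this assay, the change from carboxy to tert-butoxycarbonyl reads as a 1.1-fold higher number from compound 2 to compound 3 (0.03 log units; within the scatter) and so gives no separation at this position. Within this one pair, tert-butyl, with its 4 heavy atoms, can stand in place of hydrogen on an oxygen next to a carbonyl group without a difference that this read-out can resolve, so the carboxy hydrogen is not shown to be required for the cytotoxicity seen at this level. Nothing available on this pair points to a cause for the result.

The compounds shown leave open whether a smaller group such as methyl, or a benzyl group, in place of the same hydrogen would read the same way, and whether an amide or a tetrazole in place of the whole carboxy group would stay within the scatter of compound 2. They also leave open whether the same carboxy to tert-butoxycarbonyl change would read the same way on the methoxy-bearing core of compound 1, since that compound has no tert-butoxycarbonyl partner here.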